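A few compounds are considered here, and "the series" means these few. Any claim that something is new, unique, unknown or untested is made for them only; others in the source may bear on it.

Measured so far in this series:

- compound 1 `Cc1ncnc2c1c(-c1cc3ccccc3o1)cn2[C@@H]1O[C@H](CO)[C@@H](O)[C@H]1O`: in a functional assay on CCRF-CEM cells (Homo sapiens), read by MTT assay, with a stated time of 72 h (on this read-out higher numbers stand for weaker inhibition and lower numbers for stronger inhibition), compound 1 gives 17300 nM
- compound 2 `Cc1nc(N)c2c(-c3cc4ccccc4o3)cn([C@@H]3O[C@H](CO)[C@@H](O)[C@H]3O)c2n1`: in this assay compound 2 gives only a limit of the assay, > 20000 nM
- compound 3 `Cc1ncnc2c1c(-c1ccsc1)cn2[C@@H]1O[C@H](CO)[C@@H](O)[C@H]1O`: in this assay compound 3 gives 11200 nM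

Compound 1 and compound 2 carry the same 1-benzofuran-2-yl group on the same kind of sugar-bearing fused core, but the difference between the two cores is not broken down here. Compound 3 is reached from compound 1 by thiophen-3-yl in place of 1-benzofuran-2-yl on an aromatic carbon. The measured outcome of that exchange is a 1.5-fold lower number from compound 1 to compound 3 (0.19 log units; within the scatter), so in this pair the shift from the larger bicyclic aromatic to the smaller five-membered one leaves the read-out in this assay essentially where it stood.

Compound 4 `Cc1nc(N)c2c(-c3ccsc3)cn([C@@H]3O[C@H](CO)[C@@H](O)[C@H]3O)c2n1` has not been measured in this assay. It is reached from compound 2 by thiophen-3-yl in place of 1-benzofuran-2-yl on an aromatic carbon, the same change as from compound 1 to compound 3, at a place described in identical words. The expected step is a step that the limit leaves unreadable from compound 2 to compound 4, on the grounds that the same change gave a 1.5-fold lower number from compound 1 to compound 3 (0.19 log units; within the scatter). The starting point here is not a number: compound 2 stands at the limit of > 20000 nM in this assay, at which 1 of the 3 values shown sits. Compound 4 is therefore expected to lie near 22000 nM, within a range from 9000 nM to 50000 nM. That expectation rests on compound 2 standing at the limit of > 20000 nM in this assay, at which 1 of the 3 values shown sits, and on the earlier step of a 1.5-fold lower number from compound 1 to compound 3 (0.19 log units; within the scatter), and a limit rather than a number is as likely an outcome as not.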

Compound 4, half-maximal inhibitory concentration: > 20000 nM
Compound 4: only a limit was reported; the forecaster's own chance of this, stated with the estimate: 60%; the middle value lies beyond the limit too.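

No step from compound 2 to compound 4 can be read, since in this assay neither compound gives a number, only the same limit of the assay: the limit of > 20000 nM in this assay, at which 2 of the 4 values shown sit.

The compounds shown leave open whether thiophen-3-yl in place of 1-benzofuran-2-yl changes the read-out at all on the core shared by compound 2 and compound 4, and where either compound would stand as a number.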